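A few compounds are considered here, and "the series" means these few. Any claim that something is new, unique, unknown or untested is made for them only; others in the source may bear on it.

Three analogues built on one shared core have been tested in an ADME assay on HUVEC cells (Homo sapiens) for cytotoxicity, read by MTT assay, with a stated time of 48 h; on this read-out lower numbers stand for stronger inhibition and higher numbers for weaker inhibition. Compound 1 `COc1ccc(-c2cn(/N=C/c3cc4ccccc4nc3Cl)c(N)n2)cc1` gives 12400 nM, compound 2 `Nc1nc(-c2ccc(Br)cc2)cn1/N=C/c1cc2ccccc2nc1Cl` gives 11900 nM, and compound 3 `Cc1ccc2nc(Cl)c(/C=N/n3cc(-c4ccc(Br)cc4)nc3N)cc2c1` gives 13400 nM, a number that lies within the scatter of the other two. The two measured steps, a 1.0-fold lower number from compound 1 to compound 2 (0.02 log units; within the scatter) and a 1.1-fold higher number from compound 2 to compound 3 (0.05 log units; within the scatter), both stayed within the scatter. Compound 4 `Cc1ccc2nc(Cl)c(/C=N/n3cc(-c4cccs4)nc3N)cc2c1` differs from compound 3 by thiophen-2-yl in place of 4-bromophenyl on an aromatic carbon. Among the measured compounds shown here, neither measured step concerns that part of the molecule, so no direct precedent exists; the only guidance is that the two changes tried so far left the read-out unmoved, and a step of no more than the scatter is accordingly expected in this assay. Compound 4 is thus expected to give 13000 nM, between 6000 nM and 28000 nM, which would mean a 1.0-fold lower number from compound 3 to compound 4 (0.01 log units; within the scatter).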

Compound 4, half-maximal inhibitory concentration: 38000 nM
Compound 4: middle estimate off by 2.9-fold (0.47 log units), on the low side, and the stated range ends below it.
By their numbers in this assay, from the lowest: compounds 2, 1 and 3 (each within the scatter of the next); then compound 4.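

In this assay, among the compounds shown here, thiophen-2-yl in place of 4-bromophenyl gives a 2.8-fold higher number from compound 3 to compound 4 (0.45 log units; beyond the scatter), toward weaker inhibition and the only step beyond the scatter. The read-out therefore responds to exchanging the whole aromatic ring at this carbon, whereas exchanging bromo for methoxy on that ring and adding the methyl elsewhere both stayed within the scatter. No evidence is available to explain this step. The compounds shown leave open whether a pyridine ring or an unsubstituted phenyl at this carbon would shift the number similarly.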